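The source may hold more compounds than are shown below. What is called first, only, known or untested is meant among the compounds shown, and "the series" means these compounds.

Compound 1 `COc1ccc(-c2nc(/N=C(\N)NC(C)C)sc2-c2ccc(OC)cc2)cc1`: in a functional assay with Oryctolagus cuniculus as the target (on this read-out higher numbers stand for weaker inhibition and lower numbers for stronger inhibition), compound 1 gives > 100 nM, which is a limit of the assay.
Compound 2 `COc1ccc(-c2nc(/N=C(\N)N(C)C)sc2-c2ccc(OC)cc2)cc1`: in this assay compound 2 gives 37 nM.
Compound 3 `COc1ccc(-c2nc(/N=C(\N)N3CCOCC3)sc2-c2ccc(OC)cc2)cc1`: in this assay compound 3 gives < 1000 nM, which is a limit of the assay.

Compound 1 sits at the limit of > 100 nM in this assay, at which 1 of the 3 values shown sits, so its standing among the three is known only as a limit, and one further value is a limit as well. Among the measured compounds shown here, the one readable step is an at least 2.7-fold lower number from compound 1 to compound 2 (0.43 log units; beyond the scatter). The steps a step that the limit leaves unreadable from compound 1 to compound 3 and a step that the limit leaves unreadable from compound 2 to compound 3 remain unreadable. Compound 4 `COc1ccc(-c2nc(CNC(=O)CSC)sc2-c2ccc(OC)cc2)cc1` differs from compound 1 by a group of 7 heavy atoms (4 carbon, 1 nitrogen, 1 oxygen, 1 sulfur; no ring) in place of a group of 7 heavy atoms (4 carbon, 3 nitrogen; no ring), on an aromatic carbon. For the measured compounds named here, none of the measured steps bears directly on this change: each of them keeps the carbon with a double bond to nitrogen and varies only the amine attached to it, whereas here the whole group is exchanged. Going by the values given here, with compound 1 already at a limit and no step of the same kind measured, the expectation rests on the size of the exchange alone, and a weaker result is expected. Compound 4 is expected to give 3000 nM, within 300 nM to 30000 nM. The expected step is a step that the limit leaves unreadable from compound 1 to compound 4.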

Compound 4, half-maximal inhibitory concentration: < 100 nM
Compound 4: only a limit was reported; the forecaster's own chance of this, stated with the estimate: 60%; middle value at least 30-fold (1.47 log units) away from the limit.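

Among the compounds shown here, at the aromatic carbon that bears the exchanged group, the earlier compounds varied only the amine on the carbon with a double bond to nitrogen, whereas here the whole group gives way to ((((methylsulfanyl)methyl)carbonyl)amino)methyl, and this assay shows a number no higher from compound 1 to compound 4 (the limit leaves the size open). The result therefore shows that this position tolerates a group without that carbon and its three nitrogens, with no rise in the number. In this assay, going by these compounds, compound 4 gives < 100 nM, which is a limit of the assay, so the size of this step stays open, and the steps from compound 2 and from compound 3 to compound 4 cannot be read.

The compounds shown leave open which part of the new group matters. A methoxy in place of the methylsulfanyl, or a longer chain between the carbonyl and the sulfur, would bear on that.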